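The source may report more compounds than this note shows. Statements on the series, on what has been measured and on what is new or still open speak of the compounds shown alone.

In a functional assay on MIA cells (Homo sapiens) for inhibition, read by MTT assay, with a stated time of 72 h (a lower number here means a stronger inhibitor of growth, a higher number a weaker inhibitor of growth), compound 1 `N#C/C(=C\c1ccc(Cl)cc1)C(=O)c1ccc[nH]1` gives 48000 nM and compound 2 `N#C/C(=C\c1c(F)c(F)c(F)c(F)c1F)C(=O)c1c[nH]c2ccccc12` gives 21000 nM. Compound 3 `COc1ccc(CNC(=O)/C(C#N)=C/c2ccc[nH]2)cc1` reaches only the limit of this assay at > 50000 nM. So compound 3 has no number of its own, only that limit, which is the limit of > 50000 nM in this assay, at which 1 of the 3 values shown sits. Compound 4 `COc1ccc(CNC(=O)/C(C#N)=C/c2ccco2)cc1` differs from compound 3 in one place: furan-2-yl in place of 1H-pyrrol-2-yl on a double-bonded chain carbon bound to a double-bonded chain carbon. For the measured compounds named here, no step between two measured compounds shows how such a swap plays out, and with compound 3 known only as a limit, no change beyond the usual scatter is expected in this assay. Compound 4 is estimated at 50000 nM, within the range 20000 nM to 120000 nM, a step of a number no higher from compound 3 to compound 4 (the limit leaves the size open) that is expected most likely to leave it at the limit again.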

Compound 4, concentration for 50% growth inhibition: 34000 nM
Compound 4: the middle estimate sits 1.5-fold (0.17 log units) above what was measured; the range from low to high includes it.
By their numbers in this assay, from the lowest: compounds 2, 4 and 1 (each within the scatter of the next, the first and the last beyond it). At a limit, above all of these: compound 3.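

In this assay, furan-2-yl in place of 1H-pyrrol-2-yl gives an at least 1.4-fold lower number from compound 3 to compound 4 (0.16 log units; that floor lies within the scatter). This shows that a ring with no hydrogen-bond donor at this place still gives a measurable number, though the step cannot be told apart from the scatter. Compound 3 has only a limit and not a number, so the true size of the step stays unknown: the limit of > 50000 nM in this assay, at which 1 of the 4 values shown sits.

As far as these compounds go, it remains open how an amine or a carboxylic acid in place of the ring would change the number. From the compounds shown here alone, whether the same swap gives a similar step on another core also remains open.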